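Two weak agonists and a dimethoxyphenyl replacement

The source may report more compounds than this note shows. Statements on the series, on what has been measured and on what is new or still open speak of the compounds shown alone.

Of the compounds shown here, two sharing one core have been measured in a functional assay on CHO cells for agonist activity at Free fatty acid receptor 1 (Homo sapiens), read by FLIPR and calcium flux, tested at 100 nM; on this read-out higher numbers stand for a stronger effect at the one concentration tested and lower numbers for a weaker effect. Compound 1 `Cc1cc(COc2ccc3c(c2)OCC3CC(=O)O)nn1-c1ccccc1` gives 0.98%. Compound 2 `Cc1nc(-c2cccc3ccccc23)sc1COc1ccc2c(c1)OCC2CC(=O)O` gives 8.53%, the larger of the two numbers, yet the gap to compound 1 is within the usual scatter, so the two cannot be told apart on these data. Going by the values given here, both numbers are small, meaning that at the single concentration tested neither compound switches the receptor on to any notable degree.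

Compound 3 `COc1cc(OC)cc(-c2nc(C)c(COc3ccc4c(c3)OCC4CC(=O)O)s2)c1` has not yet been measured. It differs from compound 2 in one spot: 3,5-dimethoxyphenyl in place of naphthalen-1-yl on an aromatic carbon. The naphthalene leaves, and a phenyl ring carrying two methoxy groups takes its place on the carbon of the five-membered ring that sits next to the ring nitrogen and the ring sulfur.

Among the compounds with values here, no measured step shows what such a swap does here, so the expectation rests on the two values only. In this assay the step from compound 2 to compound 3 is expected to be a number 2.5 percentage points lower from compound 2 to compound 3 (within the scatter), which is nothing beyond the scatter. Compound 3 is therefore estimated to give 6%, within a range from -5% to 20%.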

Compound 3, a percentage reported as activity, at one concentration (the size of the read-out at that concentration, not a potency): 17.5%
For compound 3 the middle estimate is 11.5 percentage points below the measured one; low and high end bracket the measured number.
By their numbers in this assay, from the lowest: compounds 1, 2 and 3 (each within the scatter of the next, the first and the last beyond it).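

In this assay, putting 3,5-dimethoxyphenyl in place of naphthalen-1-yl gives a number 9 percentage points higher from compound 2 to compound 3 (within the scatter) and so the two compounds cannot be told apart on these data. Going by these compounds alone, this is the first view of what a change at this position does, on the aromatic carbon next to the ring nitrogen and the ring sulfur: one six-membered aromatic ring with 2 hydrogen-bond acceptors stands where 2 six-membered aromatic rings of carbon only and 0 hydrogen-bond acceptors stood, with the heavy-atom count unchanged, and the read-out shows no shift beyond the scatter. Nothing at hand explains this result.

A plain phenyl ring, or a phenyl ring with a single methoxy group, would help separate the part played by the two methoxy groups from the part played by the loss of the second ring. From the compounds shown here alone, it also remains open whether another group here, such as a phenyl ring carrying an amine or a longer ethoxy chain, could move the read-out beyond the scatter.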